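A few compounds are considered here, and "the series" means these few. Any claim that something is new, unique, unknown or untested is made for them only; others in the source may bear on it.

In a toxicity assay on MDCK cells (Canis lupus familiaris) for cytotoxicity, read by crystal violet staining, with a stated time of 48 h (on this read-out lower numbers stand for higher toxicity in this test and higher numbers for lower toxicity in this test), compound 1 `CSc1ccc(CN(Cc2ccc(C(C)(C)C)cc2)Cc2cc3cc(C)ccc3[nH]c2=O)cc1` gives > 5000 nM, which is a limit and not a number. Compound 2 `Cc1ccc2[nH]c(=O)c(CN(Cc3ccc(N(C)C)cc3)Cc3ccc(C(C)(C)C)cc3)cc2c1` gives > 5000 nM, also a limit. Compound 2 therefore has no number of its own and stands with compound 1 at the limit of > 5000 nM in this assay, at which 2 of the 2 values shown sit. Compound 3 `Cc1ccc2[nH]c(=O)c(CN(Cc3ccc(C#N)cc3)Cc3ccc(C(C)(C)C)cc3)cc2c1` differs from compound 2 by one change, cyano in place of dimethylamino on an aromatic carbon, para to a large group: cyano in place of dimethylamino on an aromatic carbon. Within the data shown here, only one measured step bears on this position, a step that the two limits leave unreadable from compound 1 to compound 2, where dimethylamino replaced methylsulfanyl on an aromatic carbon. It offers neither a size nor a direction to carry forward. Among the measured compounds shown here, with that step as the only guide, the expected step that the limit leaves unreadable from compound 2 to compound 3 in this assay is none beyond the scatter. Compound 3 is estimated at 6000 nM, with an expected range from 2500 nM to 15000 nM, and most likely it too will be reported only as a limit.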

Compound 3, half-maximal cytotoxic concentration: > 5000 nM
Compound 3 ended at the assay's limit; the forecaster's own chance of this, stated with the estimate: 80%; the middle value lies beyond the limit too.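

No new step can be read among compound 1, compound 2 and compound 3, because each value is a limit and not a number: the limit of > 5000 nM in this assay, at which 3 of the 3 values shown sit. The compounds shown leave open whether methylsulfanyl, dimethylamino and cyano differ at all in cytotoxicity, and at what concentration any of these compounds becomes cytotoxic.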